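The compounds below may be only part of what the source reports. "The series", "measured", "known", "first", "only" and "open" are said of these compounds alone.

In a functional assay on the whole organism (strain Wister albino) for inhibition, with Rattus norvegicus as the target, read by paw edema, with stated times of 1 h and 24 h, at a dose of 50 mg/kg by the intraperitoneal route (on this read-out higher numbers stand for more inhibition at the one dose given (going by the name of the read-out) and lower numbers for less inhibition), compound 1 `CN1C/C(=C\c2ccccc2)C(=O)[C@]2(C1)[C@@H](c1ccccc1)CN(C)[C@@]21C(=O)Nc2ccccc21` gives 65.1%. Compound 2 `CN1C/C(=C\c2ccccc2)C(=O)[C@]2(C1)[C@@H](c1ccccc1)CN(C)[C@@]21C(=O)N(C)c2ccccc21` gives 26.5% in this assay, and the step of a number 38.6 percentage points lower from compound 1 to compound 2 (beyond the scatter) came with a methyl in place of hydrogen on an amide-type nitrogen in a ring. Compound 3 `CN1C/C(=C\c2ccc(Br)cc2)C(=O)[C@]2(C1)[C@@H](c1ccc(Br)cc1)CN(C)[C@@]21C(=O)Nc2ccccc21` gives 82.7% in this assay, the highest of the three numbers: compound 1 lies nearest to it and compound 2 furthest, both separated from it by more than the usual scatter.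

Compound 4 `CN1C/C(=C\c2ccc(Br)cc2)C(=O)[C@]2(C1)[C@@H](c1ccc(Br)cc1)CN(C)[C@@]21C(=O)N(C)c2ccccc21` differs from compound 3 by methyl in place of hydrogen on an amide-type nitrogen in a ring. Going by the values given here, the only measured step bearing on this change is the one from compound 1 to compound 2, where the same change on the unbrominated pair gave a large fall in this assay. A fall of similar size is therefore expected for compound 4, since the change a number 38.6 percentage points lower from compound 1 to compound 2 (beyond the scatter) was well beyond the scatter. The estimated step is a number 38.7 percentage points lower from compound 3 to compound 4 (beyond the scatter). Compound 4 is expected to give about 44% in this assay, with a likely range from 25% to 65%.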

Compound 4, a percentage reported as inhibition, in the whole organism at one dose (the size of the read-out at that dose, not a potency): 83.5%
For compound 4 the middle estimate is 39.5 percentage points below the measured one; the measured number lies above the stated range.
By their numbers in this assay, from the lowest: compound 2; then compound 1; then compounds 3 and 4 (each within the scatter of the next).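

In this assay, the step on the brominated core is a number 0.8 percentage points higher from compound 3 to compound 4 (within the scatter), so methyl in place of the amide hydrogen does not carry a fixed penalty at this position. Compounds 1 and 2 alone suggested that the amide hydrogen was needed for a high number, yet compound 4 keeps a high number without it. The outcome of this one change therefore depends on the core that carries it: the same change on two cores in this assay, a number 38.6 percentage points lower (beyond the scatter) from compound 1 to compound 2 and a number 0.8 percentage points higher (within the scatter) from compound 3 to compound 4, 39.4 percentage points apart, beyond the scatter of two such steps

The two cores differ in two places, so the compounds shown do not tell whether a single bromine on either phenyl ring would be enough to produce this difference between the cores. As far as these compounds go, whether an ethyl group or a longer chain on the same nitrogen would follow the pattern of methyl on each core also remains open.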